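Removing the Chloro Group from the Hydrazone Aryl Ring

The source may report more compounds than this note shows. Statements on the series, on what has been measured and on what is new or still open speak of the compounds shown alone.

Measured compounds:
- compound 1, `COc1ccc(OC)c(/C=C/c2nnc(Nc3ccc(Cl)cc3)o2)c1`, 40500 nM
- compound 2, `COc1ccc(OC)c(/C=C/C(=O)N/N=C/c2ccc(Cl)cc2)c1`, 816 nM

Two compounds share the dimethoxyphenyl vinyl fragment and were tested in a functional assay on EKVX cells (Homo sapiens) for antiproliferative activity, read by sulforhodamine B assay, with a stated time of 48 h; a lower number here means a stronger inhibitor of growth, a higher number a weaker inhibitor of growth. Compound 1 gives 40500 nM, whereas compound 2 gives 816 nM. Compound 2 therefore stands at the lowest number of the two, and its gap to compound 1 lies beyond the scatter, so compound 2 is the stronger inhibitor of growth in this pair. The two structures differ in more than one place, so what separates them cannot be tied to a single change.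

The next compound, compound 3, has the structure `COc1ccc(OC)c(/C=C/C(=O)N/N=C/c2ccccc2)c1`. It differs from compound 2 by hydrogen in place of chloro on an aromatic carbon. Among the measured compounds shown here, no measured pair shows this exact change, so its effect is not known from the numbers in hand. The chloro group is small and sits far from the rest of the molecule, so the expectation is a step from compound 2 to compound 3 of a 1.8-fold higher number from compound 2 to compound 3 (0.26 log units; within the scatter), toward a somewhat weaker inhibitor but not clearly beyond the scatter. Compound 3 is accordingly expected to give about 1500 nM, within a range from 500 nM to 5000 nM in this assay.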

Compound 3, concentration for 50% growth inhibition: 1590 nM
Compound 3: middle estimate off by 1.1-fold (0.03 log units), on the low side, within the range that was stated.
By their numbers in this assay, from the lowest: compounds 2 and 3 (each within the scatter of the next); then compound 1.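

Among the compounds shown here, this is the first comparison in the set that isolates a single change: going from 4-chlorophenyl to phenyl, on an aromatic carbon para to a large group, gives a 1.9-fold higher number from compound 2 to compound 3 (0.29 log units; within the scatter) in this assay. The chloro group can therefore be replaced by hydrogen at this position without a difference that stands out from the scatter, so compound 2 and compound 3 cannot be ranked against each other, and the growth inhibition seen in this pair does not depend on the chlorine in any way these numbers can detect. Nothing measured on these compounds explains why the step is this small.

As far as these compounds go, what remains open is whether a different group on this same carbon, such as a methoxy group, a dimethylamino group or a carboxylic acid, would shift the number beyond the scatter, as hydrogen does not. The large gap between compound 1 and the other two also remains tied to no single structural change, as compound 1 differs from each of them in more than one place.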